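Hydroxyphenyl Positional Isomers Against Human Topoisomerase 1

The compounds below may be only part of what the source reports. "The series", "measured", "known", "first", "only" and "open" are said of these compounds alone.

Three related compounds were examined for a single read-out. Compound 1 `Oc1ccc(-c2cc(-c3ccsc3)cc(-c3cccc(O)c3)n2)cc1` has in an assay on isolated protein for inhibition of DNA topoisomerase 1 (Homo sapiens), with a stated time of 30 min, tested at 20 uM (a higher number here means a stronger effect of the compound at the concentration tested, a lower number a weaker effect), the entry "not determined" (no result reported). Compound 2 `Oc1ccc(-c2cc(-c3ccccn3)cc(-c3cccc(O)c3)n2)cc1` has in this assay the entry "not determined" (no result reported), so for these two no number exists. Compound 3 `Oc1cccc(-c2cc(-c3cccnc3)cc(-c3ccccc3O)n2)c1` is the only member of the set with a reported figure: in this assay compound 3 gives 0%, which is the only number shown and leaves it without any neighbour to be ranked against. For the measured compounds named here, no step between measured compounds can be formed from this set.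

Compound 4 `Oc1ccc(-c2cc(-c3cccnc3)cc(-c3cccc(O)c3)n2)cc1` differs from compound 3 by 4-hydroxyphenyl in place of 2-hydroxyphenyl on an aromatic carbon. The two have the same atoms, joined differently. Since compound 3 gives 0%, the account rests on that single value alone. With nothing else to lean on, the step from compound 3 to compound 4 is estimated at a number 2 percentage points higher from compound 3 to compound 4 (within the scatter), which means no movement beyond the usual scatter in either direction. On that basis compound 4 is expected to give about 2% in this assay, with a plausible range from -8% to 15%.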

Compound 4, a percentage reported as inhibition, at one concentration (the size of the read-out at that concentration, not a potency): 2.8%
Compound 4: middle estimate off by 0.8 percentage points, on the low side, within the range that was stated.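

In this assay, 4-hydroxyphenyl in place of 2-hydroxyphenyl on the aromatic carbon next to the ring nitrogen gives a number 2.8 percentage points higher from compound 3 to compound 4 (within the scatter), so the two isomers cannot be told apart in this read-out. This pair gives the set its first comparison, with the 3-hydroxyphenyl and pyridin-3-yl groups held constant, and it shows that, for these two placements of the hydroxyl group on this ring, the choice makes no difference beyond the usual scatter. Nothing else shown bears on why this is so.

The compounds shown leave open whether any other kind of group at this position would separate from compound 3 and compound 4, for instance a phenyl ring carrying an amine or a carboxylic acid in place of the hydroxyl group, or a longer chain between the ring and the core. They also leave open whether the result would hold with the pyridin-3-yl group exchanged for another ring, and whether a different concentration or a different read-out would distinguish the two isomers.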